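This account rests on a few compounds, and the source may have more. Where it says the series, first, only, none or still open, it means among the compounds named here.

Measured so far in a functional assay on SV5A8 cells (Homo sapiens) for cytotoxicity; a lower number here means a stronger inhibitor, a higher number a weaker inhibitor:
- Compound 1, `Cc1ccc2c(NCc3ccc(NC(=O)C4CCN(C5CCCCC5)CC4)cc3)nc(N(C)C)nc2c1`: > 8320 nM
- Compound 2, `Cc1ccc2c(NCc3ccc(NC(=O)C4CCN(Cc5ccco5)CC4)cc3)nc(N(C)C)nc2c1`: > 20000 nM
- Compound 3, `Cc1ccc2c(NCc3ccc(NC(=O)C4CCN(Cc5ccccc5F)CC4)cc3)nc(N(C)C)nc2c1`: > 6670 nM

Each of these three values is a limit of the assay, not a number. Compound 3 stands at the limit of > 6670 nM in this assay, at which 1 of the 3 values shown sits, so its place among the others cannot be read. Compound 1 sits at the limit of > 8320 nM in this assay, at which 1 of the 3 values shown sits, and compound 2 at the limit of > 20000 nM in this assay, at which 1 of the 3 values shown sits.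

The next compound, compound 4, `Cc1ccc(CN2CCC(C(=O)Nc3ccc(CNc4nc(N(C)C)nc5cc(C)ccc45)cc3)CC2)cc1`, differs from compound 3 by one change: 4-methylphenyl in place of 2-fluorophenyl on a saturated chain carbon bound to an amine nitrogen in a ring. The measured steps that touch the same place are a step that the two limits leave unreadable from compound 2 to compound 3 and a step that the two limits leave unreadable from compound 1 to compound 3, and both stay unreadable because the limit of > 6670 nM in this assay, at which 1 of the 3 values shown sits, caps what compound 3 can show. For the measured compounds named here, no step at this position has given a readable size, so no change beyond the scatter can be expected in this assay either way; the likeliest outcome is again a limit.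

Compound 4 is therefore expected to give about 15000 nM, most plausibly between 4000 nM and 60000 nM. The step this estimate implies is a step that the limit leaves unreadable from compound 3 to compound 4.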

Compound 4, half-maximal inhibitory concentration: > 4150 nM
Compound 4 gave a limit, no number (the forecaster's own chance of this, stated with the estimate: 85%); the middle value is on the limit's open side.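

In this assay compound 4 gives > 4150 nM, a limit and not a number, so its steps from compound 1, compound 2 and compound 3 cannot be read. The compounds shown leave open whether changing the group on the amine nitrogen in a ring alters the read-out at all.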